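Aryl-thiophene thiazolidinone series: methoxy to hydrogen step

The compounds below may be only part of what the source reports. "The series", "measured", "known", "first", "only" and "open" are said of these compounds alone.

Compound 1, `Cc1ccc(-c2cc(/N=C3/NC(=O)CS3)cs2)cc1`, in a functional assay on HCT-116 cells (Homo sapiens) for cytotoxicity, read by MTT assay, with a stated time of 72 h (a higher number here means a weaker inhibitor, a lower number a stronger inhibitor), gives > 50000 nM, a limit of the assay rather than a number.
Compound 2, `COc1ccc(-c2cc(/N=C3/NC(=O)CS3)cs2)cc1`, in this assay gives > 50000 nM, again a limit and not a number.

Among the compounds with values here, compound 2 thus stands at the limit of > 50000 nM in this assay, at which 2 of the 2 values shown sit, where compound 1 also sits, and the one measured step, a step that the two limits leave unreadable from compound 1 to compound 2, is unreadable. Compound 3, `O=C1CS/C(=N\c2csc(-c3ccccc3)c2)N1`, differs from compound 2 by hydrogen in place of methoxy on an aromatic carbon. No readable step bears on this change. Since both measured compounds sit at the limit of > 50000 nM in this assay, at which 2 of the 2 values shown sit, compound 3 is expected to remain there as well. The estimate for compound 3 is 70000 nM, within 25000 nM to 200000 nM. The expected step that the limit leaves unreadable from compound 2 to compound 3 is none beyond the scatter.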

Compound 3, half-maximal inhibitory concentration: > 50000 nM
Compound 3 ended at the assay's limit (the forecaster's own chance of this, stated with the estimate: 80%); the middle value does not contradict the limit.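

No step can be read among compound 1, compound 2 and compound 3, since each result is a limit of the assay and not a number: the limit of > 50000 nM in this assay, at which 3 of the 3 values shown sit.

Going by these compounds, whether any group at this place gives a readable value in this assay stays open.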